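A few compounds are considered here, and "the series" means these few. Any claim that something is new, unique, unknown or untested is made for them only; others in the source may bear on it.

Two close relatives have been measured in a physicochemical assay for solubility, in phosphate buffer, at pH 7.4; on this read-out higher numbers stand for higher solubility and lower numbers for lower solubility. Compound 1 `CC(C)n1cc(-c2ccnc3[nH]c(C4CCN(CC(=O)N5CCCC5)CC4)cc23)ccc1=O` gives 260000 nM, and compound 2 `CC(C)n1cc(-c2ccnc3[nH]c(C4CCN(CC(=O)N(C)C)CC4)cc23)ccc1=O` gives 110000 nM, the lower of the two numbers. Compound 3 `CN(C)C(=O)CN1CCC(c2cc3c(-c4ccc(=O)n(C)c4)ccnc3[nH]2)CC1` has not been measured yet. It differs from compound 2 in one place: methyl in place of isopropyl on an aromatic nitrogen. Within the data shown here, the only measured step is a 2.4-fold lower number from compound 1 to compound 2 (0.37 log units; beyond the scatter), from dimethylamino in place of pyrrolidin-1-yl on a carbonyl carbon. Among the measured compounds shown here, that change sits on a carbonyl carbon and not on the aromatic nitrogen, so it is a rough guide to size only, and no measured step tests the new change. A modest step no larger than that one is therefore expected, tentatively upward. The expected change is a 1.6-fold higher number from compound 2 to compound 3 (0.21 log units; within the scatter). In this assay compound 3 is estimated at 180000 nM, with a range from 70000 nM to 450000 nM.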

Compound 3, solubility: > 1000000 nM
Compound 3 was reported as a limit (the forecaster's own chance of this, stated with the estimate: 10%); middle value at least 5.5-fold (0.74 log units) away from the limit.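

In this assay, the aromatic nitrogen proves to be a sensitive position: methyl in place of isopropyl there gives an at least 9.0-fold higher number from compound 2 to compound 3 (0.95 log units; beyond the scatter). That step is clearly larger than the only other one seen, on a carbonyl carbon, which is a 2.4-fold lower number from compound 1 to compound 2 (0.37 log units; beyond the scatter). Compound 3 stands at a limit of the assay, so the new step gives only a minimum size and not a full one: the limit of > 1000000 nM in this assay, at which 1 of the 3 values shown sits.

The compounds shown leave open how an ethyl or a cyclopropyl group on the same nitrogen would read, and so whether the number climbs gradually as the group gets smaller or jumps only at methyl. They also leave open whether methyl on that nitrogen has a similar effect when pyrrolidin-1-yl sits on the carbonyl carbon.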